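A few compounds are considered here, and "the series" means these few. Any claim that something is new, unique, unknown or untested is made for them only; others in the source may bear on it.

Compound 1 `COc1cc2c(/C=C3/C(=O)N(C)c4ccccc43)c(Cl)n(C)c2cc1C` and compound 2 `COc1cc2c(/C=C3/C(=O)N(C)c4ccc(O)cc43)c(Cl)n(C)c2cc1C` share one core, and compound 3 `COc1cc2c(/C=C3/C(=O)N(C)c4ccccc43)c[nH]c2cc1C` and compound 4 `COc1cc2c(/C=C3/C(=O)N(C)c4ccc(O)cc43)c[nH]c2cc1C` share another; how the two cores differ is not broken down here. In a functional assay on cells (Cancer cell lines, Homo sapiens) for inhibition, with a stated time of 48 h (on this read-out lower numbers stand for stronger inhibition of growth and higher numbers for weaker inhibition of growth), compound 1 gives 380 nM, and in the same assay compound 2 gives 260 nM. The change between them is hydroxy in place of hydrogen on an aromatic carbon, and its step is a 1.5-fold lower number from compound 1 to compound 2 (0.16 log units; within the scatter). Compound 3 stands apart from both: in this assay compound 3 gives 7760 nM, the highest of the three numbers, and its gap to compound 1 and to compound 2 lies beyond the scatter. Compound 4 is not yet measured in this assay. The change from compound 3 to compound 4 is hydroxy in place of hydrogen on an aromatic carbon, the same change as that from compound 1 to compound 2, placed the same way on a ring of the same kind. Going by the values given here, since the only measured instance of this change moved the number within the scatter, the expectation for compound 4 is a step of about a 1.4-fold lower number from compound 3 to compound 4 (0.15 log units; within the scatter) from compound 3, resting on the step from compound 1 to compound 2 and on the value of compound 3 in this assay. On that basis compound 4 is expected to give about 5500 nM in this assay, with a likely range from 2500 nM to 12000 nM.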

Compound 4, concentration for 50% growth inhibition: 5620 nM
Compound 4: middle estimate off by 1.0-fold (0.01 log units), on the low side; the measured number falls inside the stated range.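

On the second core, hydroxy in place of hydrogen on an aromatic carbon gives, in this assay, a 1.4-fold lower number from compound 3 to compound 4 (0.14 log units; within the scatter). Set beside the step on the first core, the change carries over with no difference that can be told: the same change on two cores in this assay, a 1.5-fold lower number (0.16 log units; within the scatter) from compound 1 to compound 2 and a 1.4-fold lower number (0.14 log units; within the scatter) from compound 3 to compound 4, 1.1-fold (0.02 log units) apart, within the scatter of two such steps Both steps lie within the scatter, so the pair shows only that this change leaves the number about where it stood on each of these two cores; a change with so small a step is a weak test of carrying over, and the pair shows neither that a larger step would carry over in the same way nor that the result would hold on any further core or in any other read-out.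

The compounds shown hold only hydroxy at this place, so it remains open whether methoxy, an amine or a carboxylic acid on the same aromatic carbon would move the number further, and whether such a step would match on both cores. They also leave open which of the parts that separate the two cores goes with the much higher numbers on the second core, since no compound shown takes those parts apart one at a time.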